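The source may hold more compounds than are shown below. What is called first, only, known or untested is meant among the compounds shown, and "the series" means these compounds.

Measured so far in a functional assay on MCF7 cells (Homo sapiens) for inhibition, read by MTT assay, with a stated time of 72 h; a lower number here means a stronger inhibitor, a higher number a weaker inhibitor:

Compound 1 `C=CCc1ccc(OCc2ccc(Cl)cc2Cl)c(-c2ccc(O)c(CC=C)c2)c1`: 27400 nM
Compound 2 `C=CCc1ccc(OCc2ccc(Cl)c(Cl)c2)c(-c2ccc(O)c(CC=C)c2)c1`: 17500 nM

With only these two numbers to compare, compound 2 has a single neighbour, compound 1. The two lie within the usual scatter of repeated measurements, so neither can be ranked above the other.

The next compound, compound 3 `C=CCc1ccc(OCc2c(Cl)cccc2Cl)c(-c2ccc(O)c(CC=C)c2)c1`, keeps the shared core and changes only where the two chlorines sit: 2,6-dichlorophenyl in place of 3,4-dichlorophenyl on a saturated chain carbon bound to an oxygen on an aromatic ring. In words, this puts 2,6-dichlorophenyl in place of 3,4-dichlorophenyl on a saturated chain carbon bound to an oxygen on an aromatic ring.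

Within the data shown here, one measured step bears on this, since it also only relocates the two chlorines: a 1.6-fold lower number from compound 1 to compound 2 (0.19 log units; within the scatter). That step stayed within the scatter. It is a single step, however, and the 2,6-dichlorophenyl group has not yet been measured, so the evidence is thin. No shift beyond the scatter is therefore expected in this assay.

The estimated step is a 1.3-fold higher number from compound 2 to compound 3 (0.10 log units; within the scatter). For compound 3 the expected value is 22000 nM, with an estimated range from 10000 nM to 50000 nM.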

Compound 3, half-maximal inhibitory concentration: 19400 nM
Estimate against measurement, compound 3: 1.1-fold (0.05 log units) above; measured number inside the range.
By their numbers in this assay, from the lowest: compounds 2, 3 and 1 (each within the scatter of the next).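

Across the three compounds, the placement of the two chlorines on this ring has yet to produce a difference that can be read in this assay: replacing 3,4-dichlorophenyl with 2,6-dichlorophenyl gives (a 1.1-fold higher number from compound 2 to compound 3 (0.04 log units; within the scatter)), and replacing 2,4-dichlorophenyl with the same group gives (a 1.4-fold lower number from compound 1 to compound 3 (0.15 log units; within the scatter)). The earlier pair could compare only two arrangements, whereas three now lie within the scatter of one another, so at this position, on a saturated chain carbon bound to an oxygen on an aromatic ring, these relocations of the chlorines cannot be ranked. Nothing available explains why the numbers stay so close.

Going by these compounds, all three compounds carry two chlorines on this ring, so it remains open whether a different group there, such as a trifluoromethyl group, a methoxy group or an amine, would move the number beyond the scatter. The shared core is also the same in all three, which leaves open what a change elsewhere, such as replacing its hydroxyl group with a carboxylic acid, would do in this assay.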